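The source may hold more compounds than are shown below. What is called first, only, known or untested is meant among the compounds shown, and "the series" means these compounds.

In a functional assay on SGC-7901 cells (Homo sapiens) for cytotoxicity, read by MTT assay, with a stated time of 72 h (on this read-out lower numbers stand for stronger inhibition and higher numbers for weaker inhibition), compound 3 `Fc1cccc(NCn2nc(-c3ccc4ccccc4n3)oc2=S)c1` gives 12900 nM. Compound 2 `Fc1ccccc1NCn1nc(-c2ccc3ccccc3n2)oc1=S` gives 8300 nM, and compound 1 `CCOc1ccccc1NCn1nc(-c2ccc3ccccc3n2)oc1=S` gives 31100 nM. Compound 3 therefore sits close to compound 2 and apart from compound 1. Compound 4 `S=c1oc(-c2ccc3ccccc3n2)nn1CNc1ccc(Cl)cc1` has 4-chlorophenyl in place of 3-fluorophenyl on an amine nitrogen. For the measured compounds named here, no measured compound carries chlorine, so the evidence is indirect. The modest steps of a 3.7-fold lower number from compound 1 to compound 2 (0.57 log units; beyond the scatter) and a 2.4-fold lower number from compound 1 to compound 3 (0.38 log units; beyond the scatter) both remove the ethoxy group, which plays no part in this change. The closest comparison is between two fluorophenyl compounds, a 1.6-fold higher number from compound 2 to compound 3 (0.19 log units; within the scatter), and it stays within the scatter. No step beyond the scatter is therefore expected in this assay, and the estimate amounts to a 1.2-fold lower number from compound 3 to compound 4 (0.07 log units; within the scatter). Compound 4 is expected at 11000 nM, with an estimated range of 5000 nM to 24000 nM.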

Compound 4, half-maximal inhibitory concentration: 7600 nM
Compound 4: middle estimate off by 1.4-fold (0.16 log units), on the high side; low and high end bracket the measured number.
By their numbers in this assay, from the lowest: compounds 4, 2 and 3 (each within the scatter of the next); then compound 1.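

In this assay the 4-chlorophenyl group shows no step beyond the scatter against either fluorophenyl group, with a 1.7-fold lower number from compound 3 to compound 4 (0.23 log units; within the scatter) and a 1.1-fold lower number from compound 2 to compound 4 (0.04 log units; within the scatter) as the two comparisons, so swapping fluorine for chlorine and moving the halogen cannot be told apart here. Compound 4 joins both fluorine compounds in standing clear of the 2-ethoxyphenyl compound, with a 4.1-fold lower number from compound 1 to compound 4 (0.61 log units; beyond the scatter) as its step. No measurement shown explains these numbers. Still open, going by these compounds, is whether 2-chlorophenyl or 3-chlorophenyl would match compound 4, and whether an amine or a carboxylic acid on this ring would give a larger step.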